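Swapping Isopropyl for Ethoxyphenyl on a Triazole Nitrogen

The compounds below may be only part of what the source reports. "The series", "measured", "known", "first", "only" and "open" are said of these compounds alone.

The series is built on a shared core carrying a sulfanyl group and a second ring system, varied only at one aromatic nitrogen. Compound 1 `COc1ccc(-n2c(S)nnc2Sc2nnc(-c3ccccc3)n2-c2ccccc2)cc1` was entered in a functional assay on HT-29 cells (Homo sapiens) for inhibition, read by MTT assay, with a stated time of 48 h (on this read-out higher numbers stand for weaker inhibition and lower numbers for stronger inhibition), and returned "not determined" (no result reported). Compound 3 `CC(C)n1c(S)nnc1Sc1nnc(-c2ccccc2)n1-c1ccccc1` was likewise entered in this assay and returned "not determined" (no result reported), so compound 3 stands without a single number, and it shares that standing with one further entry. Among the compounds with values here, the one member with a figure is compound 2 `Sc1nnc(CSc2nnc(-c3ccccc3)n2-c2ccccc2)n1-c1ccccc1`, which in this assay gives 5490 nM. Compound 4 `CCOc1ccc(-n2c(S)nnc2Sc2nnc(-c3ccccc3)n2-c2ccccc2)cc1` has not yet been tested; it differs from compound 3 by 4-ethoxyphenyl in place of isopropyl on an aromatic nitrogen. Within the data shown here, since no pair of measured compounds differing in one place exists here, no step in this assay is available to set the size or direction of this change; the author expects at most a modest shift, likely within the scatter of the method. Compound 4 is therefore estimated, because compound 2 gives 5490 nM as the only anchor, at 6000 nM in this assay, with a range from 1500 nM to 25000 nM.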

Compound 4, half-maximal inhibitory concentration: 46800 nM
For compound 4 the middle estimate is 7.8-fold (0.89 log units) below the measured one, outside the stated range (above it).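

Within the data shown here, compound 3 has no single number in this assay so no step between it and compound 4 can be read. The compounds shown leave open how isopropyl and 4-ethoxyphenyl on the aromatic nitrogen compare. No available evidence bears on the result for compound 4.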